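The source may hold more compounds than are shown below. What is called first, only, known or untested is meant among the compounds shown, and "the series" means these compounds.

The measured compounds in a functional assay on HCT-116 cells (Homo sapiens) for antiproliferative activity, read by MTT assay, with a stated time of 24 h; a lower number here means a stronger inhibitor, a higher number a weaker inhibitor:
Compound 1 `COc1ccc(/C=C/C(=O)c2ccc(OC)c3c2OC(C)(C)C=C3)c(F)c1` gives > 10000 nM, which is a limit of the assay rather than a number.
Compound 2 `COc1ccc(C(=O)/C=C/c2ccc(N(c3ccccc3)c3ccccc3)cc2)c2c1C=CC(C)(C)O2` gives > 10000 nM, again only a limit.
Compound 3 `COc1ccc(C(=O)/C=C/c2ccc(OC)c(OC)c2OC)c2c1C=CC(C)(C)O2` gives > 10000 nM, likewise a limit.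

Compound 1 therefore stands at the limit of > 10000 nM in this assay, at which 3 of the 3 values shown sit, and none of the three measured compounds separates itself from the others. No change between two measured compounds is recorded, so nothing within this set shows how large a change at this part of the molecule can be.

Compound 4 `COc1ccc(C(=O)/C=C/c2ccsc2)c2c1C=CC(C)(C)O2` differs from compound 1 in one place: thiophen-3-yl in place of 2-fluoro-4-methoxyphenyl on a double-bonded chain carbon bound to a double-bonded chain carbon. The shared core of compound 1 is kept, and the change sits on the carbon chain between the core and the aromatic ring.

The step in this assay is expected to be a step that the limit leaves unreadable from compound 1 to compound 4, that is, nothing beyond the scatter of the measurement. Compound 4 is estimated to give 15000 nM, within a range of 4000 nM to 60000 nM, and the assay is expected most likely to report only a limit again.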

Compound 4, half-maximal inhibitory concentration: > 10000 nM
Compound 4 was reported as a limit (the forecaster's own chance of this, stated with the estimate: 75%); the middle value does not contradict the limit.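

In this assay, compound 1 and compound 4 are both reported only as limits, so no step between them can be read: the limit of > 10000 nM in this assay, at which 4 of the 4 values shown sit.

The compounds shown leave open how thiophen-3-yl and 2-fluoro-4-methoxyphenyl truly compare, and what change, if any, would bring a value within the readable range of this assay.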